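A few compounds are considered here, and "the series" means these few. Any claim that something is new, unique, unknown or untested is made for them only; others in the source may bear on it.

In a functional assay on NCI-H460 cells (Homo sapiens) for cytotoxicity, read by MTT assay, with a stated time of 24 h (on this read-out lower numbers stand for stronger inhibition and higher numbers for weaker inhibition), compound 1 `C#CCn1c(=O)c(C=O)cc2cc(C)ccc21` gives > 100000 nM as a limit of the assay, not a number. Among the measured compounds shown here, compound 2 `C#CCn1c(=O)c(/C=C/C(=O)/C=C(O)/C=C/c2ccc(O)c(OC)c2)cc2ccccc21` reads 25400 nM in this assay and holds the only actual number so far. Compound 3 `C#CCn1c(=O)c(/C=C/C(=O)/C=C(O)/C=C/c2ccc(O)c(OC)c2)cc2cc(F)ccc21` carries the change fluoro in place of hydrogen on an aromatic carbon on the shared core, fluoro in place of hydrogen on an aromatic carbon. For the measured compounds named here, no measured step shows this change, and the only anchor is compound 2 at 25400 nM for now. The expected move is a 1.2-fold lower number from compound 2 to compound 3 (0.06 log units; within the scatter) and stays within the usual scatter, with no direction favoured. For this assay compound 3 is estimated at 22000 nM within an expected range from 10000 nM to 50000 nM as a working figure.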

Compound 3, half-maximal inhibitory concentration: 44300 nM
Estimate against measurement, compound 3: 2.0-fold (0.30 log units) below, within the range that was stated.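

The series now has its first step in one place: in this assay, fluoro in place of hydrogen on an aromatic carbon of the shared core gives a 1.7-fold higher number from compound 2 to compound 3 (0.24 log units; within the scatter). Compound 2 and compound 3 therefore cannot be ordered, and a single fluorine at this position leaves the read-out within the scatter. Compound 1 remains a limit of the assay and not a number: the limit of > 100000 nM in this assay, at which 1 of the 3 values shown sits.

As far as these compounds go, whether an amine, a methoxy group or a carboxylic acid at this position would give a step beyond the scatter stays open. The compounds shown also leave open how the read-out responds to changes elsewhere on the shared core.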